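The source may hold more compounds than are shown below. What is called first, only, known or untested is meant among the compounds shown, and "the series" means these compounds.

Measured so far:
Compound 1 `CCC(C)(C)Cc1c[nH]c(CCc2ccc(-c3ccccc3O)cc2)n1` gives 31 nM in an assay on isolated protein for binding affinity to Bombesin receptor subtype-3 (Homo sapiens); a lower number here means a stronger inhibitor, a higher number a weaker inhibitor.
Compound 2 `CCC(C)(C)Cc1c[nH]c(CCc2ccc(N3CCCC[C@@H]3C(=O)O)cc2)n1` gives 5.3 nM.
Compound 3 `CCC(C)(C)Cc1c[nH]c(CCc2ccc(N3CCCC[C@@H]3c3ncn[nH]3)cc2)n1` gives 26 nM.

Among these three, compound 2 stands lowest, with both steps to it beyond the scatter: a 5.8-fold lower number from compound 1 to compound 2 (0.77 log units; beyond the scatter) and, going the other way, a 4.9-fold higher number from compound 2 to compound 3 (0.69 log units; beyond the scatter). Compound 4 `CCC(C)(C)Cc1c[nH]c(CCc2ccc(N3CCCc4cn[nH]c43)cc2)n1` has not been measured. It differs from compound 2 in one place: a group of 9 heavy atoms (6 carbon, 3 nitrogen; one five-membered aromatic ring with 2 hetero atoms, one six-membered non-aromatic ring with 1 hetero atom) in place of a group of 9 heavy atoms (6 carbon, 1 nitrogen, 2 oxygen; one six-membered non-aromatic ring with 1 hetero atom), on an aromatic carbon. Going by the values given here, the step that bears most on this change is the one from compound 2 to compound 3, where the carboxy on the saturated ring gave way to an aromatic five-membered ring holding nitrogen and the number rose modestly. Compound 4 likewise loses the carboxy and gains an aromatic five-membered ring with two hetero atoms, here fused to the six-membered non-aromatic ring, so a rise of similar size is expected rather than no change. Compound 4 is therefore estimated at 25 nM, with a range of 8 nM to 80 nM, an expected step of a 4.7-fold higher number from compound 2 to compound 4 (0.67 log units; beyond the scatter).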

Compound 4, half-maximal inhibitory concentration: 18 nM
For compound 4 the middle estimate is 1.4-fold (0.14 log units) above the measured one; measured number inside the range.
By their numbers in this assay, from the lowest: compound 2; then compounds 4, 3 and 1 (each within the scatter of the next).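

In this assay, the group entering on this aromatic carbon matches 2-carboxypiperidin-1-yl in heavy atoms, hydrogen-bond donors and acceptors and in having no net charge, yet the change brings a 3.4-fold higher number from compound 2 to compound 4 (0.53 log units; beyond the scatter), so those counts alone do not preserve the number of compound 2. Set against the 2-hydroxyphenyl group, the same group gives a 1.7-fold lower number from compound 1 to compound 4 (0.24 log units; within the scatter), so the two groups cannot be told apart in this assay. Nothing measured here explains either step.

The compounds shown leave open whether a carboxylic acid added to the entering group of compound 4 would bring its number back towards that of compound 2. They also leave open how a tetrazole or a primary amide in place of the carboxy of compound 2 would behave.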